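Lengthening the chain of compound 3

This account rests on a few compounds, and the source may have more. Where it says the series, first, only, none or still open, it means among the compounds named here.

Three compounds have numbers in a functional assay on ileum (Cavia porcellus) for antagonist activity, with a stated time of 30 s; on this read-out lower numbers stand for stronger inhibition and higher numbers for weaker inhibition. Compound 1 (`O=C(O)c1cc(=O)c2c(OCCCCCCCOc3ccccc3)cccc2o1`) gives 0.8 ug/mL and compound 2 (`O=C(O)c1cc(=O)c2ccc(OCCCCCSc3ccccc3)cc2o1`) gives 0.4 ug/mL. Compound 3 (`O=C(O)c1cc(=O)c2cccc(OCCCOc3ccccc3)c2o1`) gives 50 ug/mL, the highest number of the three and the weakest inhibition, with both gaps beyond the scatter.

The next compound is compound 4 (`O=C(O)c1cc(=O)c2cccc(OCCCCCOc3ccccc3)c2o1`), not yet measured. The change from compound 3 is 2-phenoxyethyl in place of phenoxy on a saturated chain carbon, three bonds along the chain from an oxygen on an aromatic ring.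

Among the compounds with values here, no measured pair isolates this change, so the evidence is indirect. The chains of compound 1 at 0.8 ug/mL and compound 2 at 0.4 ug/mL are both longer than that of compound 3, but both compounds also differ from it in other ways. A move to a lower number in this assay is therefore expected, beyond the scatter but probably short of those two values. The expected step is an 8.3-fold lower number from compound 3 to compound 4 (0.92 log units; beyond the scatter). The estimate for compound 4 is 6 ug/mL, with an expected range of 1 ug/mL to 30 ug/mL.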

Compound 4, half-maximal inhibitory concentration: 9 ug/mL
Compound 4: middle estimate off by 1.5-fold (0.18 log units), on the low side; the range from low to high includes it.
By their numbers in this assay, from the lowest: compounds 2 and 1 (each within the scatter of the next); then compound 4; then compound 3.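

In this assay, 2-phenoxyethyl in place of phenoxy on a saturated chain carbon, three bonds along the chain from an oxygen on an aromatic ring, gives a 5.6-fold lower number from compound 3 to compound 4 (0.74 log units; beyond the scatter) on an unchanged core. Within the data shown here, this is the first pair that differs in one place, so chain length at this position now has a direct reading, and the step lies beyond the scatter. Nothing measured here accounts for the size of the step.

On these data alone, with a single step, it remains open whether a longer chain at this position would lower the number further or whether the trend would stop or reverse. As far as these compounds go, it is also open how the number would respond to an amine in place of the chain oxygen that carries the phenyl ring.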